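Replacing the 4-methylpyridin-3-yl group of compound 1

The compounds below may be only part of what the source reports. "The series", "measured", "known", "first", "only" and "open" are said of these compounds alone.

Among the measured compounds shown here, in a physicochemical assay for solubility, in phosphate buffer, with a stated time of 2 h, at pH 6.5 (a lower number here means a less soluble compound, a higher number a more soluble compound), compound 1 `Cc1ccncc1C(=O)N1CC(Oc2cncc(N3C(=O)c4ccc(Cl)cc4C3(C)C)c2)C1` gives 290 ug/mL, the highest of the three numbers measured so far. Compound 3 `CC1(C)c2cc(Cl)ccc2C(=O)N1c1cncc(N2CCN(S(C)(=O)=O)CC2)c1` gives 91 ug/mL, and compound 2 `CC1(C)c2cc(Cl)ccc2C(=O)N1c1cncc(OC2CN(C(=O)c3ncccc3Cl)C2)c1` gives 20 ug/mL.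

The next compound is compound 4 `Cn1cc(C(=O)N2CC(Oc3cncc(N4C(=O)c5ccc(Cl)cc5C4(C)C)c3)C2)cn1`, with 1-methyl-1H-pyrazol-4-yl in place of 4-methylpyridin-3-yl on a carbonyl carbon. The counted difference is 1-methyl-1H-pyrazol-4-yl in place of 4-methylpyridin-3-yl on a carbonyl carbon.

For the measured compounds named here, only one measured step bears on this place: a 15-fold lower number from compound 1 to compound 2 (1.16 log units; beyond the scatter), a large step beyond the scatter, with 3-chloropyridin-2-yl in place of 4-methylpyridin-3-yl on a carbonyl carbon. Going by the values given here, compound 3 does not carry this carbonyl group and offers no matching step. Among the compounds with values here, the evidence is therefore thin: one step, with a different incoming group, and no measured compound carrying 1-methyl-1H-pyrazol-4-yl.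

That step shows that the number can fall sharply when this group changes. Compound 1 already stands at the top of the measured values with 290 ug/mL, so a fall is more likely than a rise. A smaller fall than the one seen for 3-chloropyridin-2-yl is expected, estimated as a 2.6-fold lower number from compound 1 to compound 4 (0.42 log units; beyond the scatter).

Compound 4 is estimated at 110 ug/mL, with an expected range of 35 ug/mL to 300 ug/mL.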

Compound 4, solubility: 310 ug/mL
Beside the measured number, compound 4's estimate is 2.8-fold (0.45 log units) below it, and the stated range ends below it.
By their numbers in this assay, from the lowest: compound 2; then compound 3; then compounds 1 and 4 (each within the scatter of the next).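

In this assay, the group on this carbonyl carbon can move from a six-membered to a five-membered aromatic ring with no change beyond the scatter: the step to 1-methyl-1H-pyrazol-4-yl is a 1.1-fold higher number from compound 1 to compound 4 (0.03 log units; within the scatter). The large fall seen with 3-chloropyridin-2-yl is therefore not a general outcome of losing 4-methylpyridin-3-yl, and the step between the two incoming groups at the same place is a 16-fold higher number from compound 2 to compound 4 (1.19 log units; beyond the scatter), so among these three compounds the entering group decides whether a large step appears. Nothing measured here accounts for why these groups differ in this assay.

Open questions remain at the same carbonyl carbon, since all three groups compared there are aromatic rings, and a saturated ring such as morpholine or an open chain ending in an amine or a carboxylic acid would test whether the high numbers extend beyond them. A plain pyridin-2-yl group would also help separate the contribution of the chloro group from that of the ring in the large step to compound 2.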